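The source may hold more compounds than are shown below. What is called first, only, known or untested is meant among the compounds shown, and "the series" means these compounds.

Three compounds have been measured in an assay on isolated protein (Oryctolagus cuniculus) with Thromboxane-A synthase (Homo sapiens) as the target, tested at 1 uM; on this read-out lower numbers stand for less inhibition and higher numbers for more inhibition at the one concentration tested (going by the name of the read-out):

Compound 1, `Cn1nc(-c2cccnc2)c2ccccc2c1=O`, gives 63%.
Compound 2, `CC(C)n1nc(-c2cccnc2)c2ccccc2c1=O`, gives 87%.
Compound 3, `O=c1c2ccccc2c(-c2cccnc2)nn1CC1CCCCC1`, gives 98%.

Compound 2 stands second highest of these three numbers: compound 3 lies above it, a number 11 percentage points higher from compound 2 to compound 3 (beyond the scatter), and compound 1 lies below it, a number 24 percentage points higher from compound 1 to compound 2 (beyond the scatter). The new compound 4, `O=C(c1cccs1)n1nc(-c2cccnc2)c2ccccc2c1=O`, changes compound 2 at a single place: (thiophen-2-yl)carbonyl in place of isopropyl on an aromatic nitrogen.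

For the measured compounds named here, two measured steps bear on this, since both also change the group on the same aromatic nitrogen of the shared core. Replacing methyl by isopropyl gave a number 24 percentage points higher from compound 1 to compound 2 (beyond the scatter), and replacing isopropyl by cyclohexylmethyl gave a number 11 percentage points higher from compound 2 to compound 3 (beyond the scatter). In both, a larger group on that nitrogen went with more inhibition. The (thiophen-2-yl)carbonyl group is larger than isopropyl, but it is a different kind of group, with a carbonyl and an aromatic ring rather than a saturated chain, and nothing measured here tells how such a group behaves. The expectation is therefore a modest rise at most, a number 1 percentage points higher from compound 2 to compound 4 (within the scatter), with a wide range. Compound 4 is estimated at 88%, between 60% and 99%.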

Compound 4, a percentage reported as inhibition, at one concentration (the size of the read-out at that concentration, not a potency): 37%
Beside the measured number, compound 4's estimate is 51 percentage points above it; measured number below the stated range.
By their numbers in this assay, from the lowest: compound 4; then compound 1; then compound 2; then compound 3.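

In this assay, (thiophen-2-yl)carbonyl on the aromatic nitrogen gave a number 50 percentage points lower from compound 2 to compound 4 (beyond the scatter) when it replaced isopropyl, a number 61 percentage points lower from compound 3 to compound 4 (beyond the scatter) when it replaced cyclohexylmethyl and a number 26 percentage points lower from compound 1 to compound 4 (beyond the scatter) when it replaced methyl . Group size alone therefore does not set the number at this position: inhibition rose along the saturated groups from methyl to cyclohexylmethyl, yet this larger group, with its carbonyl and five-membered aromatic ring, falls below all three, and compound 4 is the one that goes against the earlier trend. No measurement at hand accounts for this drop.

The compounds shown leave open whether the carbonyl or the thiophene ring goes with the fall. An acetyl group or a thiophen-2-ylmethyl group on the same nitrogen would separate the two.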